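This account rests on a few compounds, and the source may have more. Where it says the series, first, only, none or still open, it means among the compounds named here.

Measured so far in an ADME assay on microsomes from liver (Rattus norvegicus) for metabolic stability, read by LC-MS, using NADPH, with a stated time of 30 min, tested at 0.1 uM; a lower number here means that less of the compound is left, a higher number that more of the compound is left:
compound 1 `Nc1cccc(-c2ccc3nccc(-c4ccncc4)c3n2)c1`: 61%
compound 2 `CS(=O)(=O)Nc1ccc2nccc(-c3ccncc3)c2n1`: 94%
compound 3 `O=S(=O)(NCCN1CCCC1)c1cccc(-c2ccc3nccc(-c4ccnc(C(F)(F)F)c4)c3n2)c1`: 16%

Compound 1 stands second highest of the three; compound 2 sits above it, and compound 3, which carries a sulfonamide on the phenyl and a trifluoromethyl on the pyridine, sits well below it, both gaps beyond the scatter.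

Compound 4 `O=S(=O)(c1cccc(-c2ccc3nccc(-c4ccncc4)c3n2)c1)N1CC[C@H](O)C1` is yet to be measured. Against compound 1 the change is (3-hydroxypyrrolidin-1-yl)sulfonyl in place of amino on an aromatic carbon.

Within the data shown here, only one step is on hand, a number 33 percentage points higher from compound 1 to compound 2 (beyond the scatter), and it exchanges the whole 3-aminophenyl for methanesulfonamido, so it does not bear directly on keeping the phenyl and changing the group on it. Compound 3 is the closer reference in structure, since it also carries a sulfonyl group on the phenyl, but it differs from compound 1 in two places, so its low value cannot be split between them.

On this basis a downward step is expected, of uncertain size; the expected step is a number 26 percentage points lower from compound 1 to compound 4 (beyond the scatter), with a wide range given the lack of a direct comparison. For compound 4 the estimate in this assay is 35%, between 12% and 62%.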

Compound 4, percent of the compound remaining: 10%
The estimate for compound 4 lay 25 percentage points above the measured number; the measured number lies below the stated range.
By their numbers in this assay, from the lowest: compounds 4 and 3 (each within the scatter of the next); then compound 1; then compound 2.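

With the phenyl kept and only the group on it exchanged, (3-hydroxypyrrolidin-1-yl)sulfonyl in place of amino gives a number 51 percentage points lower from compound 1 to compound 4 (beyond the scatter) in this assay. This reads the position on its own, which the step to compound 2 could not do, as that step replaces the whole 3-aminophenyl. The group on this aromatic carbon therefore matters for the percent of compound remaining, and a ring carrying a hydroxyl on the sulfonyl does not hold compound 4 near the level of compound 1 at 61% in this series, although no measurement at hand explains the step.

Still open, going by these compounds, is which part of the entering group goes with the lower number: the sulfonyl link, the pyrrolidine ring or its hydroxyl, which a methylsulfonyl, a primary sulfonamide or a plain pyrrolidin-1-ylsulfonyl at the same place would help to separate. Also open, on these data alone, is whether the opposite stereoisomer of the alcohol reads the same, and how far a smaller group in place of amino, such as an acetamide or a carboxylic acid, stays near compound 1.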